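A few compounds are considered here, and "the series" means these few. Any claim that something is new, unique, unknown or untested is made for them only; others in the source may bear on it.

Compound 1 `Cc1[nH]c2ccccc2c1C1CC(c2ccncc2)=NO1` and compound 2 `COc1ccc2c(C3CC(c4ccncc4)=NO3)c[nH]c2c1` share a common framework, though the difference between their two cores is not broken down here. In a functional assay on CWR22R cells (Homo sapiens) for inhibition, read by MTT assay, with a stated time of 48 h (on this read-out lower numbers stand for stronger inhibition and higher numbers for weaker inhibition), compound 1 gives 17300 nM and compound 2 gives 16300 nM, two numbers within the usual scatter of each other. Compound 3 `Cc1c(C2CC(c3ccncc3)=NO2)c2ccccc2n1Cc1ccc(Cl)cc1` differs from compound 1 by 4-chlorobenzyl in place of hydrogen on an aromatic nitrogen, and in this assay compound 3 gives 8330 nM, a step of a 2.1-fold lower number from compound 1 to compound 3 (0.32 log units; beyond the scatter). Compound 4 `COc1ccc2c(C3CC(c4ccncc4)=NO3)cn(Cc3ccc(Cl)cc3)c2c1` has not yet been measured; it differs from compound 2 by 4-chlorobenzyl in place of hydrogen on an aromatic nitrogen. This is the same kind of change as that from compound 1 to compound 3, though only in compound 1 does the aromatic nitrogen lie next to the ring atom that bears a methyl group. For compound 4 in this assay a step of about a 2.0-fold lower number from compound 2 to compound 4 (0.31 log units; beyond the scatter) is expected, because the same kind of change gave a 2.1-fold lower number from compound 1 to compound 3 (0.32 log units; beyond the scatter). Compound 4 is therefore estimated at 8000 nM, with a likely range from 4000 nM to 16000 nM.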

Compound 4, half-maximal inhibitory concentration: 17300 nM
Compound 4: middle estimate off by 2.2-fold (0.33 log units), on the low side; measured number above the stated range.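

In this assay, 4-chlorobenzyl in place of hydrogen on the aromatic nitrogen gives a 1.1-fold higher number from compound 2 to compound 4 (0.03 log units; within the scatter) and so brings no readable shift on this core. Set beside the earlier step, this result cannot be told apart from it: the same change on two cores in this assay, a 2.1-fold lower number (0.32 log units; beyond the scatter) from compound 1 to compound 3 and a 1.1-fold higher number (0.03 log units; within the scatter) from compound 2 to compound 4, 2.2-fold (0.34 log units) apart, within the scatter of two such steps. The data therefore show neither that the change carries over from one core to the other nor that it fails to, and two cores cannot establish a rule for the series.

The compounds shown leave open what other groups on that aromatic nitrogen would do, such as an unsubstituted benzyl, a longer carbon chain or a chain ending in an amine. They also leave open whether the chlorine contributes to either step.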